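From 4-methylphenyl to 2-chloro-4-nitrophenyl at the limit

A few compounds are considered here, and "the series" means these few. Any claim that something is new, unique, unknown or untested is made for them only; others in the source may bear on it.

Values from an ADME assay on RAW264.7 cells (Mus musculus) for cytotoxicity, read by MTT assay, with a stated time of 48 h (on this read-out higher numbers stand for weaker inhibition and lower numbers for stronger inhibition), stand as follows:
- Compound 1 `COc1ccc(NC(=S)OCCNC(=O)C(C)(C)Oc2ccc(Cl)cc2)cc1` gives > 800000 nM as a limit
- Compound 2 `Cc1ccc(NC(=S)OCCNC(=O)C(C)(C)Oc2ccc(Cl)cc2)cc1` gives > 800000 nM as a limit

Compound 2 stands at > 800000 nM in this assay as a limit of the assay and not as a number. Among the compounds with values here, the only measured step is a step that the two limits leave unreadable from compound 1 to compound 2 and offers no size to carry forward. All that the data show is the limit of > 800000 nM in this assay, at which 2 of the 2 values shown sit, with no number behind either compound.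

Compound 3 `CC(C)(Oc1ccc(Cl)cc1)C(=O)NCCOC(=S)Nc1ccc([N+](=O)[O-])cc1Cl` keeps the shared core but carries a different group. The change is 2-chloro-4-nitrophenyl in place of 4-methylphenyl on an amide-type nitrogen with 2-chloro-4-nitrophenyl in place of 4-methylphenyl on an amide-type nitrogen. Within the data shown here, no measured step involves this exchange, so the data supply neither a size nor a direction, and no step beyond the usual scatter is expected in this assay on this evidence. Compound 3 may well be reported only as a limit again. The expected step is a number no higher from compound 2 to compound 3 (the limit leaves the size open) as an estimate without a firm direction. The estimate for compound 3 is 800000 nM with 250000 nM to 1500000 nM as its expected range.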

Compound 3, half-maximal inhibitory concentration: > 800000 nM
Compound 3: only a limit was reported (the forecaster's own chance of this, stated with the estimate: 65%); the middle value sits exactly at the limit.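

In this assay compound 3 gives > 800000 nM, again a limit of the assay and not a number. Within the data shown here, no step among compound 1, compound 2 and compound 3 can be read. The compounds shown leave open whether their three aromatic groups differ at all in this assay, since all that can be stated is one shared boundary: the limit of > 800000 nM in this assay, at which 3 of the 3 values shown sit.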